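A pyrimidinyl ether in place of a thiadiazolyl thioether

This account rests on a few compounds, and the source may have more. Where it says the series, first, only, none or still open, it means among the compounds named here.

Of the compounds shown here, three sharing one core have been tested. Going by the values given here, in a functional assay on Jurkat cells (Homo sapiens) for inhibition (on this read-out higher numbers stand for weaker inhibition and lower numbers for stronger inhibition), compound 2 `Cc1nnc(SCC(=O)[C@H](CC(=O)O)NC(=O)[C@@H](NC(=O)COc2cccc3ccccc23)C(C)C)s1` gives 190000 nM, the only number among the three results. Compound 1 `CC(C)[C@H](NC(=O)COc1cccc2ccccc12)C(=O)N[C@@H](CC(=O)O)C(=O)CSc1nc(-c2ccccc2)c(-c2ccccc2)[nH]1` reaches only the limit > 200000 nM in this assay. Compound 3 `CC(C)[C@H](NC(=O)COc1cccc2ccccc12)C(=O)N[C@@H](CC(=O)O)C(=O)CSc1nc2ccccc2s1` likewise returns the limit > 200000 nM. The step of an at least 1.0-fold higher number from compound 2 to compound 3 (0.02 log units; that floor lies within the scatter) stays within the scatter, as the limit of > 200000 nM in this assay, at which 2 of the 3 values shown sit, shows. Compound 4 `CC(C)[C@H](NC(=O)COc1cccc2ccccc12)C(=O)N[C@@H](CC(=O)O)C(=O)COc1nccc(C(F)(F)F)n1` carries (4-(trifluoromethyl)pyrimidin-2-yl)oxy in place of (5-methyl-1,3,4-thiadiazol-2-yl)sulfanyl on a saturated chain carbon bound to a carbonyl carbon. Among the compounds with values here, no measured step touches this change; the one step that is known, on a sulfur, leaves the read-out near the limit, so no step beyond the scatter is expected for no change at the digits printed from compound 2 to compound 4 (within the scatter). Compound 4 is therefore estimated at 190000 nM, between 60000 nM and 400000 nM, with a real chance that only a limit is reported.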

Compound 4, half-maximal inhibitory concentration: > 200000 nM
Compound 4 ended at the assay's limit; the forecaster's own chance of this, stated with the estimate: 55%; at least 1.0-fold (0.02 log units) between middle value and limit.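

The change on a saturated chain carbon bound to a carbonyl carbon now extends beyond sulfur-linked rings: with an oxygen link and a six-membered aromatic ring, this assay shows an at least 1.0-fold higher number from compound 2 to compound 4 (0.02 log units; that floor lies within the scatter). Compound 3 and compound 4 both stand at limits, so the step joining them cannot be read. None of the groups shown at this position brings the read-out clear of the limit: the limit of > 200000 nM in this assay, at which 3 of the 4 values shown sit.

On these data alone, what stays open is whether a phenoxy group or an amine on this carbon would give a number well clear of that limit.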